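This account rests on a few compounds, and the source may have more. Where it says the series, first, only, none or still open, it means among the compounds named here.

Measured in a physicochemical assay for solubility, measured as kinetic solubility; a higher number here means a more soluble compound, a lower number a less soluble compound:
Compound 1 `COC(c1cc(Cl)c2c(c1Cl)C(=O)N(Cc1c(C)cc(C)[nH]c1=O)CC2)C1CCOC1`: 415000 nM; 457000 nM; 439000 nM; 436000 nM (4 entries)
Compound 2 `Cc1cc(C)c(CN2CCc3c(Cl)cc(-c4c(C)noc4C)c(Cl)c3C2=O)c(=O)[nH]1`: 93000 nM

The repeat entries of compound 1 stand close together (the several entries of compound 1 in this assay, 415000 nM; 457000 nM; 439000 nM; 436000 nM (4 entries)), so its level is well defined. Compound 2 has a single number, 93000 nM, and one further entry gave no single number. Among the measured compounds shown here, on these figures, compound 2 lies below compound 1, which reads 415000 nM; 457000 nM; 439000 nM; 436000 nM (4 entries), although the two differ in more than one simple exchange and no clean step connects them.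

Compound 3 `Cc1cc(C)c(CN2CCc3c(Cl)cc([C@@H](CO)[C@H]4CCCO4)c(Cl)c3C2=O)c(=O)[nH]1` has not yet been measured in this assay. It departs from compound 2 on an aromatic carbon, where the 3,5-dimethyl-1,2-oxazol-4-yl group gives way to a new group bearing a five-membered non-aromatic ring (a group of 8 heavy atoms (6 carbon, 2 oxygen; one five-membered non-aromatic ring with 1 hetero atom) in place of a group of 7 heavy atoms (5 carbon, 1 nitrogen, 1 oxygen; one five-membered aromatic ring with 2 hetero atoms), on an aromatic carbon).

Compound 1 also carries a five-membered non-aromatic ring with 1 hetero atom instead of the 3,5-dimethyl-1,2-oxazol-4-yl group, and compound 1 reads 415000 nM; 457000 nM; 439000 nM; 436000 nM (4 entries). On that single comparison, an upward move beyond the scatter is expected, and the estimated move is a 3.0-fold higher number from compound 2 to compound 3 (0.48 log units; beyond the scatter). For compound 3 the estimate is 280000 nM, with an expected range from 120000 nM to 480000 nM.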

Compound 3, solubility: 576000 nM
Estimate against measurement, compound 3: 2.1-fold (0.31 log units) below, outside the stated range (above it).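

With compound 3, this aromatic carbon, ortho to a chloro group and para to a fused ring, gains its first readable step in this assay: replacing the 3,5-dimethyl-1,2-oxazol-4-yl group with the group bearing a five-membered non-aromatic ring gives a 6.2-fold higher number from compound 2 to compound 3 (0.79 log units; beyond the scatter). Among the compounds shown here, this single exchange on the shared core therefore moves the read-out beyond the scatter, which compound 1 and compound 2 could not show, as no clean step connects them. Several things change together in this step, however: an aromatic ring gives way to a non-aromatic one, the hydrogen-bond donors go from 0 to 1, and 2 defined stereocentres enter, and nothing measured here bears on which of these accounts for the step.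

The compounds shown leave open how much of the step belongs to each of those features, and how the other stereoisomers of the entering group would read. Going by these compounds, it also remains open whether a group of another kind at this aromatic carbon, such as a morpholine ring, an amine or a carboxylic acid, would read close to compound 3 or close to compound 2.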